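Amine replacement at the shared core, compound 2 to 4

A few compounds are considered here, and "the series" means these few. Any claim that something is new, unique, unknown or untested is made for them only; others in the source may bear on it.

Compound 2 `CNC(=O)c1cc(Oc2ccc(Nc3nccc(N4CCCC4)n3)cc2)ccn1` is measured in a functional assay on HCT-116 cells (Homo sapiens) for inhibition, read by MTT assay, with a stated time of 72 h, tested at 20 uM (a higher number here means more inhibition at the concentration tested (going by the name of the read-out), a lower number less inhibition), and gives 66.4% there. Compound 3 `CN(c1ccc(Oc2ncnc3ccsc23)cc1)c1nccc(N2CCc3ccccc32)n1` gives 57.8% in this assay, a number within the usual scatter of that of compound 2, so the two cannot be told apart. Compound 1 `CN(c1ccc(Oc2ncnc3sccc23)cc1)c1nccc(N2CCCCC2)n1` gives 52.2% in this assay, and its gap to compound 2 lies beyond the scatter. Going by the values given here, compounds 1 and 3 are built on a different core from compound 2, so no single-point step among the measured compounds is available.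

Compound 4 `CNC(=O)c1cc(Oc2ccc(Nc3nccc(N4CCc5ccccc5C4)n3)cc2)ccn1` keeps the core of compound 2 and differs in one place: 1,2,3,4-tetrahydroisoquinolin-2-yl in place of pyrrolidin-1-yl on an aromatic carbon. The measured set holds no comparison of this change on any core, so the expectation rests on compound 2 alone.

The step of a number 4.4 percentage points lower from compound 2 to compound 4 (within the scatter) is expected to be small, in either direction, and most likely not beyond the scatter. Compound 4 is therefore estimated at 62% in this assay, with a range from 45% to 78%.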

Compound 4, a percentage reported as inhibition, at one concentration (the size of the read-out at that concentration, not a potency): 31.2%
Beside the measured number, compound 4's estimate is 30.8 percentage points above it; measured number below the stated range.
By their numbers in this assay, from the lowest: compound 4; then compounds 1, 3 and 2 (each within the scatter of the next, the first and the last beyond it).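

Going by these compounds alone, replacing pyrrolidin-1-yl with 1,2,3,4-tetrahydroisoquinolin-2-yl gives the first single-point step: in this assay, a number 35.2 percentage points lower from compound 2 to compound 4 (beyond the scatter). This position, on an aromatic carbon next to the ring nitrogen, is therefore not indifferent to the amine it carries, even though the hydrogen-bond donor and acceptor counts and the net charge of the group stay the same. Nothing available accounts for the loss of inhibition.

As far as these compounds go, it remains open whether the step goes with the six-membered non-aromatic ring or with the added six-membered aromatic ring of carbon only. Morpholin-4-yl or an open-chain dimethylamino group at this position on the core of compound 2 would give further single-point comparisons with compound 2.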